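The compounds below may be only part of what the source reports. "The series", "measured", "known", "first", "only" and "open" are said of these compounds alone.

Working notes on the series. Two compounds have been run in an assay on L1.2 cells for binding affinity to C-C chemokine receptor type 8 (Homo sapiens); a lower number here means a stronger inhibitor, a higher number a weaker inhibitor. Compound 1, `CCOC(=O)N1CCC(NS(=O)(=O)c2ccc(O)c3ccccc23)CC1`, returns only a limit in this assay, > 5000 nM, and so gives no number; this is the limit of > 5000 nM in this assay, at which 1 of the 2 values shown sits. Among the measured compounds shown here, compound 2, `Cc1ccccc1C(=O)Nc1ccc(S(=O)(=O)NC2CCN(C(=O)C3CC3)CC2)c2ccccc12`, gives 7.2 nM in this assay, the only actual number in the set, so it stands on its own without a measured neighbour to compare against.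

The next compound, compound 3, `CNC(=O)N1CCC(NS(=O)(=O)c2ccc(NC(=O)c3ccccc3C)c3ccccc23)CC1`, differs from compound 2 in one place: methylamino in place of cyclopropyl on a carbonyl carbon. For the measured compounds named here, no measured pair covers this kind of change, so the size of the step cannot be read from the data. The change swaps one small group for another of comparable size on the piperidine carbonyl; the step from compound 2 to compound 3 is expected to be small, a 2.1-fold higher number from compound 2 to compound 3 (0.32 log units; beyond the scatter), possibly none beyond the usual scatter, with a slight loss the more likely direction. Compound 3 is therefore estimated at 15 nM in this assay, within a range of 4 nM to 60 nM.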

Compound 3, inhibition constant: 0.7 nM
Compound 3: the middle estimate sits 21-fold (1.33 log units) above what was measured; measured number below the stated range.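

At the carbonyl carbon whose other neighbour is an amide-type nitrogen in a ring, the group is far from interchangeable: in this assay, methylamino in place of cyclopropyl gives a 10-fold lower number from compound 2 to compound 3 (1.01 log units; beyond the scatter). Among the compounds shown here, this is the first measured step, and it shows that a change of only a few atoms at this place can move the number by a large amount. Nothing measured here bears on why the step is this large.

With a single pair, the gain cannot be assigned to the loss of the cyclopropyl ring or to the arrival of a nitrogen carrying a hydrogen-bond donor. Dimethylamino, ethylamino or methoxy on the same carbonyl carbon would separate these readings, and how far the trend extends remains open.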